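This account rests on a few compounds, and the source may have more. Where it says the series, first, only, none or still open, it means among the compounds named here.

Measured compounds:
compound 2 `N[C@H]1CC[C@H](Nc2c(C(=O)NCc3ccc(Oc4ccccc4)cc3)nc(Br)c3cccnc23)CC1` — 7900 nM
compound 3 `CS(=O)(=O)NCCCN(c1nc(C(=O)NCc2ccc(F)cc2)c(O)c2ncccc12)S(C)(=O)=O` — > 20000 nM
compound 1 `O=C(NCc1ccc(F)cc1)c1nc(Br)c2cccnc2c1NCc1ccccc1` — "not determined" (no result reported)

All three share one core and were tested in a functional assay on MCF7 cells (Homo sapiens) for cytotoxicity, read by MTT assay, with a stated time of 72 h; on this read-out higher numbers stand for weaker inhibition and lower numbers for stronger inhibition. Compound 2 gives 7900 nM in this assay. For compound 3 the assay returned only a limit, > 20000 nM, which is not a number (the limit of > 20000 nM in this assay, at which 1 of the 3 values shown sits). Compound 1 carries no value in this assay at all, so it stands on none of the numbers shown; it enters the story only through its structure.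

Compound 4 `NCCNc1c(C(=O)NCc2ccc(F)cc2)nc(Br)c2cccnc12` is the untested compound. It differs from compound 1 in one place: aminomethyl in place of phenyl on a saturated chain carbon bound to a nitrogen on an aromatic ring. Among the compounds with values here, no measured step runs between two compounds here, and compound 2 and compound 3 each differ from compound 4 in several places at once. They give only a rough bracket: one yields a number, the other only a limit. The change from compound 1 to compound 4 is expected to move the read-out in this assay by a small amount, in no certain direction, and quite possibly not beyond the usual scatter.

Compound 4 is estimated at 12000 nM, with an expected range from 4000 nM to 40000 nM, and a real chance that this assay reports only a limit.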

Compound 4, half-maximal inhibitory concentration: 6000 nM
For compound 4 the middle estimate is 2.0-fold (0.30 log units) above the measured one, within the range that was stated.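

No step can be read from the result for compound 4: compound 1, which differs from it in one place, has no reported value, and compound 2 and compound 3 differ from it in several places. Nothing shown accounts for the value of compound 4. The compounds shown leave open how replacing benzylamino with (2-aminoethyl)amino on the shared core changes the read-out.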